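The compounds below may be only part of what the source reports. "The series", "measured", "known", "first", "only" and "open" are said of these compounds alone.

Working notes on the series.

Compound 1 `COc1ncnc2c1c(-c1ccoc1)cn2[C@@H]1O[C@H](CO)[C@@H](O)[C@H]1O` is the reference point. Within the data shown here, in a functional assay on K562 cells (Homo sapiens), read by MTT assay, with a stated time of 72 h (on this read-out lower numbers stand for stronger inhibition and higher numbers for weaker inhibition), compound 1 gives 190 nM, the only number in the set. Compound 2 `Cc1ncnc2c1c(-c1ccoc1)cn2[C@@H]1O[C@H](CO)[C@@H](O)[C@H]1O` carries methyl in place of methoxy on an aromatic carbon. In this assay compound 2 gives > 20000 nM, which is a limit of the assay and not a number. The step of an at least 100-fold higher number from compound 1 to compound 2 (2.02 log units; beyond the scatter) is therefore a large loss, and its size rests on (the limit of > 20000 nM in this assay, at which 1 of the 2 values shown sits).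

Compound 3 `COc1ncnc2c1c(-c1ccccc1)cn2[C@@H]1O[C@H](CO)[C@@H](O)[C@H]1O` is not yet measured. Its change from compound 1 is phenyl in place of furan-3-yl on an aromatic carbon. Among the measured compounds shown here, no measured step in the set touches this position; the only measured step concerns methyl against methoxy on the shared core, and it says nothing about swapping the furan-3-yl for phenyl. Hence there is no direct guide in this assay, and the step from compound 1 to compound 3 could in principle fall either way, though no evidence here demands a large one.

On this basis compound 3 is expected to give about 450 nM in this assay, with a wide range from 80 nM to 4000 nM, meaning an expected step of a 2.4-fold higher number from compound 1 to compound 3 (0.37 log units; beyond the scatter).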

Compound 3, half-maximal inhibitory concentration: > 20000 nM
Compound 3 was reported as a limit (the forecaster's own chance of this, stated with the estimate: 15%); middle value at least 44-fold (1.64 log units) away from the limit.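

Until now, only the methyl against methoxy change had shown sensitivity on the shared core. The step of an at least 100-fold higher number from compound 1 to compound 3 (2.02 log units; beyond the scatter) shows in this assay that the aromatic carbon two ring bonds from the ring nitrogen also matters, and that phenyl does not stand in for furan-3-yl there. Activity at this place therefore depends on which aromatic ring is carried, and exchanging one uncharged aromatic ring for another is enough to lose it. The value of compound 3 is a limit of the assay and not a number, and the size of the step rests on it: the limit of > 20000 nM in this assay, at which 2 of the 3 values shown sit.

A single replacement cannot tell whether the loss follows from removing the ring oxygen, from going from a five-membered to a six-membered aromatic ring, or from both together. The compounds shown leave this open, and they give no reading for thiophen-3-yl, furan-2-yl, a pyridine ring or a small open chain such as ethyl at this carbon, any of which would help separate these possibilities.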